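A few compounds are considered here, and "the series" means these few. Any claim that something is new, unique, unknown or untested is made for them only; others in the source may bear on it.

Compound 1 `CC(C(=O)N1CCN(c2ccc(Cl)cc2)CC1)N1C(=O)CCC1=O`: 100%
Compound 2 `CC(C(=O)N1CCN(c2ccccc2F)CC1)N1C(=O)CCC1=O`: 50%
Compound 3 `CC(C(=O)N1CCN(c2ccc(F)cc2)CC1)N1C(=O)CCC1=O`: 50%

Of the compounds shown here, three sharing one core have been measured in a functional assay on the whole organism (strain Swiss) with Mus musculus as the target, in the maximal electroshock model, with a stated time of 0.5 h, at a dose of 300 mg/kg by the intraperitoneal route; a higher number here means a stronger effect of the compound at the dose given, a lower number a weaker effect. Compound 1 stands highest of the three, and both other compounds lie well below it: the step of a number 50 percentage points lower from compound 1 to compound 2 (beyond the scatter) and the step of a number 50 percentage points lower from compound 1 to compound 3 (beyond the scatter) are each beyond the scatter, while the step of no change at the digits printed from compound 2 to compound 3 (within the scatter) shows compound 2 and compound 3 side by side with no separation.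

The next compound, compound 4 `CCC(C(=O)N1CCN(c2ccc(Cl)cc2)CC1)N1C(=O)CCC1=O`, keeps the 4-chlorophenyl of compound 1 and changes the chain instead: methyl in place of hydrogen on a saturated chain carbon, two bonds along the chain from an amide-type nitrogen in a ring and a carbonyl carbon. Among the compounds with values here, none of the measured steps touches this chain; all three concern the aryl group on the amine nitrogen in the ring. The data therefore give no direct guide to the size of this step in this assay, and the expectation rests on compound 1 alone, whose value is the top of the scale. A step within the scatter, or a small fall from that ceiling, is expected, which means a number 10 percentage points lower from compound 1 to compound 4 (within the scatter). Compound 4 is thus estimated at 90%, with a range from 60% to 100%.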

Compound 4, a percentage reported as activity, at one dose (the size of the read-out at that dose, not a potency): 0%
For compound 4 the middle estimate is 90 percentage points above the measured one, outside the stated range (below it).
By their numbers in this assay, from the lowest: compound 4; then compounds 2 and 3 (each within the scatter of the next); then compound 1.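

In this assay, the change of methyl in place of hydrogen on a saturated chain carbon, two bonds along the chain from an amide-type nitrogen in a ring and a carbonyl carbon, gives a number 100 percentage points lower from compound 1 to compound 4 (beyond the scatter). Within the data shown here, this shows that the chain position is not a tolerant one at this dose: with the 4-chlorophenyl kept, the methyl to ethyl difference alone, a single added carbon, takes the read-out to the bottom of the scale, whereas the earlier steps, all on the aryl group, left compound 2 and compound 3 with a read-out still present. No measurement available here accounts for this loss, and the data describe its size only.

The compounds shown leave open whether a propyl or a cyclopropyl at this carbon would read like the ethyl of compound 4, and whether ethyl has the same outcome when paired with the 2-fluorophenyl or the 4-fluorophenyl. They also leave open whether compound 4 would show any effect at another dose or another time, since a single-dose read-out is not a potency.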